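The source may hold more compounds than are shown below. What is called first, only, known or untested is meant among the compounds shown, and "the series" means these compounds.

Among the measured compounds shown here, compound 3 `c1ccc2c(c1)CCC2NC1CCN(CCCc2c[nH]c3ccc(-n4cnnc4)cc23)CC1` gives 68% in a functional assay on CHO cells for activation of 5-hydroxytryptamine receptor 1D (Homo sapiens), read by GTPgammaS binding (a higher number here means a larger maximal response, a lower number a smaller maximal response), and stands lowest of the three numbers measured so far. Its nearest neighbour is compound 2 `O[C@@H]1Cc2ccccc2[C@H]1NC1CCN(CCCc2c[nH]c3ccc(-n4cnnc4)cc23)CC1`, which in this assay gives 75%; the step of a number 7 percentage points lower from compound 2 to compound 3 (within the scatter) lies within the scatter, so the two are not separated. Compound 1 `c1ccc(CNCC2CCN(CCCc3c[nH]c4ccc(-n5cnnc5)cc34)CC2)cc1` is furthest away, with 101% in this assay, and the step of a number 33 percentage points lower from compound 1 to compound 3 (beyond the scatter) is beyond the scatter.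

Compound 4 `c1cc(CNC2CCN(CCCc3c[nH]c4ccc(-n5cnnc5)cc34)CC2)co1` differs from compound 3 as follows: (furan-3-yl)methyl in place of 2,3-dihydro-1H-inden-1-yl on an amine nitrogen. The change replaces the bicyclic group of compound 3 with an arylmethyl group on the same amine nitrogen, which brings compound 4 nearer in shape to the benzyl arrangement of compound 1. For the measured compounds named here, the steps that bear on this are a number 33 percentage points lower from compound 1 to compound 3 (beyond the scatter), which was large, and a number 7 percentage points lower from compound 2 to compound 3 (within the scatter), which was within the scatter. A rise in this assay is therefore expected, recovering part but not necessarily all of the ground lost between compound 1 and compound 3. For compound 4 the estimate in this assay is 85%, within 65% to 105%, which as a step would be a number 17 percentage points higher from compound 3 to compound 4 (beyond the scatter).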

Compound 4, largest response reached (reported as efficacy), in percent of the reference or control that the assay uses: 65%
For compound 4 the middle estimate is 20 percentage points above the measured one; measured number inside the range.
By their numbers in this assay, from the lowest: compounds 4, 3 and 2 (each within the scatter of the next); then compound 1.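

Replacing 2,3-dihydro-1H-inden-1-yl with (furan-3-yl)methyl on the amine nitrogen does not separate the compounds in this assay, with a number 3 percentage points lower from compound 3 to compound 4 (within the scatter) and a number 10 percentage points lower from compound 2 to compound 4 (within the scatter). An arylmethyl group on this nitrogen is therefore not enough to reach the response of compound 1, as shown by a number 36 percentage points lower from compound 1 to compound 4 (beyond the scatter). Compounds 2, 3 and 4, each with the amine nitrogen directly on the saturated ring carbon, now form one group within the scatter, and compound 1, with its (benzylamino)methyl group, stands apart from all three.

The step from compound 1 to compound 4 changes both the aryl ring and the attachment, so a benzylamino group directly on the saturated ring carbon would be needed to separate the two. Nothing available explains the gap to compound 1.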